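The source may report more compounds than this note shows. Statements on the series, on what has been measured and on what is new or still open speak of the compounds shown alone.

Measured in a functional assay on HEK293 cells for agonist activity at trace amine-associated receptor 1 (Homo sapiens), read by cAMP accumulation, with a stated time of 30 min; on this read-out lower numbers stand for an effect already at smaller amounts and higher numbers for an effect only at larger amounts of compound:
- compound 1 `CN(C[C@H]1COC(N)=N1)c1cccc(Cl)c1`: 27 nM
- compound 2 `NC1=N[C@@H](c2ccccc2)CO1`: 67 nM

Compound 1 has the lowest of the two numbers in this assay; compound 2 sits higher, and the gap between the two lies beyond the usual scatter. Going by the values given here, no pair differing in one place has been measured, so no step size is known.

Compound 3 `CCN(C[C@H]1COC(N)=N1)c1cccc(Cl)c1` differs from compound 1 by methyl in place of hydrogen on a saturated chain carbon bound to a nitrogen on an aromatic ring. Among the compounds with values here, with no measured step of this kind, the expected change from compound 1 to compound 3 in this assay, a 1.1-fold higher number from compound 1 to compound 3 (0.05 log units; within the scatter), is small and may well stay within the scatter. Compound 3 is therefore estimated at 30 nM, with a range from 12 nM to 80 nM.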

Compound 3, half-maximal effective concentration: 29 nM
For compound 3 the middle estimate is 1.0-fold (0.01 log units) above the measured one; measured number inside the range.
By their numbers in this assay, from the lowest: compounds 1 and 3 (each within the scatter of the next); then compound 2.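

Extending methyl to ethyl at this position, on a saturated chain carbon bound to a nitrogen on an aromatic ring, gives a 1.1-fold higher number from compound 1 to compound 3 (0.03 log units; within the scatter) in this assay as the first measured step of the series. At this position, the added methyl leaves the number within the scatter, so this single step shows tolerance of ethyl in this assay and no gain from it. Nothing at hand bears on the reason for this result.

From the compounds shown here alone, whether a longer chain such as propyl, or a bulkier group such as cyclohexyl, would be tolerated here stays open. So does the outcome with an amine or a carboxylic acid at the end of this chain.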